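Isopropoxy in place of chloro: working notes

The source may report more compounds than this note shows. Statements on the series, on what has been measured and on what is new or still open speak of the compounds shown alone.

In an ADME assay on L132 cells (Homo sapiens) for cytotoxicity, read by MTT assay, with a stated time of 72 h (a higher number here means a weaker inhibitor, a lower number a stronger inhibitor), compound 2 `COc1ccc(C2=C(c3cc(OC)c(OC)c(OC)c3)C(=O)C(O)C2)cc1Cl` gives < 1 ug/mL, which is a limit. Compound 1 `COc1ccc(C2=C(c3cc(OC)c(OC)c(OC)c3)C(=O)C(O)C2)cc1NC(=O)c1ccccc1` gives > 100 ug/mL, also a limit. For the measured compounds named here, the only measured step, an at least 100-fold lower number from compound 1 to compound 2 (2.00 log units; beyond the scatter), is large and beyond the scatter, and it is a chloro in place of benzamido change on the same aromatic carbon. Compound 3 `COc1ccc(C2=C(c3cc(OC)c(OC)c(OC)c3)C(=O)C(O)C2)cc1OC(C)C` carries isopropoxy in place of chloro there: isopropoxy in place of chloro on an aromatic carbon. With that single step as a loose guide, a moderate move to a higher number is expected in this assay, well short of an at least 100-fold lower number from compound 1 to compound 2 (2.00 log units; beyond the scatter). The expected step is an at least 4.0-fold higher number from compound 2 to compound 3 (0.60 log units; beyond the scatter). For compound 3 the estimated value is 4 ug/mL, with an expected range of 0.5 ug/mL to 50 ug/mL.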

Compound 3, half-maximal inhibitory concentration: > 100 ug/mL
Compound 3 ended at the assay's limit; the forecaster's own chance of this, stated with the estimate: 35%; at least 25-fold (1.39 log units) between middle value and limit.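

In this assay, isopropoxy in place of chloro gives an at least 100-fold higher number from compound 2 to compound 3 (2.00 log units; beyond the scatter), so the gap to chloro at this aromatic carbon is not peculiar to benzamido. Compound 3 gives > 100 ug/mL, which is a limit. The step between compound 1 and compound 3 cannot be read, and the two compounds cannot be ordered: the limit of > 100 ug/mL in this assay, at which 2 of the 3 values shown sit.

Still open, from the compounds shown here alone, is how a fluoro, methyl or hydroxy group at this carbon would compare with chloro and isopropoxy. Compound 2 also stands at a limit, so the full size of both readable steps remains unknown: the limit of < 1 ug/mL in this assay, at which 1 of the 3 values shown sits.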